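A few compounds are considered here, and "the series" means these few. Any claim that something is new, unique, unknown or untested is made for them only; others in the source may bear on it.

Of the compounds shown here, two have been tested, both built on a shared core. Compound 1 `COc1cc2ncnc(Nc3ccc(F)c(Cl)c3)c2cc1NC(=O)/C=C/c1ccc(F)cc1Cl` was examined in a functional assay on MCF7 cells (Homo sapiens) for cytotoxicity, read by MTT assay, with a stated time of 72 h (a higher number here means a weaker inhibitor, a lower number a stronger inhibitor), where compound 1 is recorded as "not active" (no number reported). For the measured compounds named here, compound 2 `O=C(/C=C/c1cccc(Cl)c1Cl)Nc1cc2c(Nc3ccc(F)c(Cl)c3)ncnc2cc1O[C@H]1CCOC1` is the only member with a reported number: in this assay compound 2 gives 30100 nM, a weak result that stands alone, with no second value to rank it against. Compound 3 `COc1cc(/C=C/C(=O)Nc2cc3c(Nc4ccc(F)c(Cl)c4)ncnc3cc2O[C@H]2CCOC2)cc(OC)c1O` differs from compound 2 in one place, (4-hydroxy-3,5-dimethoxyphenyl in place of 2,3-dichlorophenyl on a double-bonded chain carbon bound to a double-bonded chain carbon). Going by the values given here, no step between two measured compounds is available, so there is no measured precedent for what such a change does here. In the absence of any such step, compound 3 is expected to remain a weak inhibitor, with an estimated value in this assay of 35000 nM, in a range from 10000 nM to 100000 nM. That estimate means a step of a 1.2-fold higher number from compound 2 to compound 3 (0.07 log units; within the scatter), which is expected to lie within the usual scatter rather than beyond it.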

Compound 3, half-maximal inhibitory concentration: 30500 nM
The estimate for compound 3 lay 1.1-fold (0.06 log units) above the measured number; low and high end bracket the measured number.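

For the compounds shown here, exchanging 2,3-dichlorophenyl for 4-hydroxy-3,5-dimethoxyphenyl gives a 1.0-fold higher number from compound 2 to compound 3 (0.01 log units; within the scatter) in this assay, the first measured step at this place, on a double-bonded chain carbon bound to a double-bonded chain carbon. The two groups differ in their counts, with 1 hydrogen-bond donor and 3 hydrogen-bond acceptors entering where the group that leaves has none, yet this difference leaves the two compounds within the scatter of each other in this assay. Nothing measured on these compounds explains that result.

Compound 1 differs from both other compounds in more than one place, so it gives no readable step. Still open, from the compounds shown here alone, is whether any group at this place would take the number beyond the scatter, for instance an amine or a carboxylic acid on the ring, or a longer chain.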